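Compound 2 to compound 4: butyl on the carbonyl

This account rests on a few compounds, and the source may have more. Where it says the series, first, only, none or still open, it means among the compounds named here.

Compound 1 `CCn1c(C(=O)NCCC(=O)OC)ccc1C(CC)(CC)c1ccc(C#CC(O)(CC)CC)c(C)c1`: > 50000 nM (a limit)
Compound 2 `CCN(CC)CCCNC(=O)c1ccc(C(CC)(CC)c2ccc(C#CC(O)(CC)CC)c(C)c2)n1CC`: 17800 nM
Compound 3 `C#CCCOC(=O)c1ccc(C(CC)(CC)c2ccc(C#CC(O)(CC)CC)c(C)c2)n1CC`: > 50000 nM (a limit)

All three compounds were tested in a functional assay on MCF7 cells (Homo sapiens) for antiproliferative activity, read by MTT assay, with a stated time of 72 h; on this read-out higher numbers stand for weaker inhibition and lower numbers for stronger inhibition. Among the measured compounds shown here, compound 2 gives 17800 nM, the only exact number in the set. Compound 1 and compound 3 both sit at the limit of > 50000 nM in this assay, at which 2 of the 3 values shown sit.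

The step to compound 4 `CCCCC(=O)c1ccc(C(CC)(CC)c2ccc(C#CC(O)(CC)CC)c(C)c2)n1CC` puts butyl in place of (3-(diethylamino)propyl)amino on a carbonyl carbon. For the measured compounds named here, two measured steps bear on it. Losing the same group from the same carbonyl carbon gave an at least 2.8-fold higher number from compound 2 to compound 3 (0.44 log units; beyond the scatter), which is the closer precedent. Changing only the end of the chain gave an at least 2.8-fold lower number from compound 1 to compound 2 (0.44 log units; beyond the scatter). Of these three compounds, only compound 2 carries the diethylamino group, and only compound 2 has an exact value.

A move to a higher number is therefore expected in this assay, on the evidence of an at least 2.8-fold higher number from compound 2 to compound 3 (0.44 log units; beyond the scatter). The expected step is a 2.5-fold higher number from compound 2 to compound 4 (0.40 log units; beyond the scatter). For compound 4 the estimate is 45000 nM, with an expected range of 20000 nM to 90000 nM.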

Compound 4, half-maximal inhibitory concentration: > 50000 nM
Compound 4 gave a limit, no number; the forecaster's own chance of this, stated with the estimate: 60%; middle value at least 1.1-fold (0.04 log units) away from the limit.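

Compound 4 stands at a limit in this assay and gives no number: the limit of > 50000 nM in this assay, at which 3 of the 4 values shown sit. On this carbonyl carbon, butyl in place of (3-(diethylamino)propyl)amino gives an at least 2.8-fold higher number from compound 2 to compound 4 (0.44 log units; beyond the scatter), so a second replacement moves in the same direction as the (but-3-yn-1-yl)oxy of compound 3, now with no oxygen or nitrogen attached to the carbonyl. The steps among compound 1, compound 3 and compound 4 cannot be read, since all three values are limits.

Among the compounds shown here, compound 2 remains the only compound with the diethylamino group and the only one with an exact value, and compound 1 shows that the amide alone does not give one. Open, on these data alone, is whether another amine at the end of the chain, such as dimethylamino or piperidine, would give a number, or whether a diethylamino group on a chain without the amide nitrogen would.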